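Aryl swap on the propanoyl piperazine arm

The compounds below may be only part of what the source reports. "The series", "measured", "known", "first", "only" and "open" are said of these compounds alone.

Measured compounds:
- compound 1, `CC[C@H](C)C(N)c1cc(C(F)(F)F)ccc1N1CCN(C(=O)CCc2ccc(Cl)cc2Cl)CC1`: 75 nM in an assay on HEK293 cells for displacement of a labelled ligand from Melanocortin receptor 4 (Homo sapiens); a higher number here means a weaker inhibitor, a lower number a stronger inhibitor
- compound 2, `CC(C)C[C@H](N)c1cc(C(F)(F)F)ccc1N1CCN(C(=O)CCc2ccccc2Cl)CC1`: 1700 nM in this assay

Within the data shown here, compound 2 stands at the highest of the two numbers; the only other measured compound, compound 1, sits far lower, and that gap is beyond the scatter. Among the measured compounds shown here, the two differ at more than one place, so no single step between them is given.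

Compound 3, `Cc1cccc(CCC(=O)N2CCN(c3ccc(C(F)(F)F)cc3[C@@H](N)CC(C)C)CC2)c1`, has not been measured. It differs from compound 2 in one place: 3-methylphenyl in place of 2-chlorophenyl on a saturated chain carbon, two bonds along the chain from a carbonyl carbon. For the measured compounds named here, no step of this kind is among the measured pairs, so the direction rests on the two values alone: compound 1, which carries more chlorine on that ring, has the lower number, and compound 3 carries none. A modest rise, not clearly beyond the scatter, is expected, a 1.5-fold higher number from compound 2 to compound 3 (0.17 log units; within the scatter). Compound 3 is estimated at 2500 nM, within 700 nM to 9000 nM.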

Compound 3, inhibition constant: 2100 nM
Estimate against measurement, compound 3: 1.2-fold (0.08 log units) above; measured number inside the range.
By their numbers in this assay, from the lowest: compound 1; then compounds 2 and 3 (each within the scatter of the next).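

In this assay, 3-methylphenyl in place of 2-chlorophenyl on a saturated chain carbon, two bonds along the chain from a carbonyl carbon, gives a 1.2-fold higher number from compound 2 to compound 3 (0.09 log units; within the scatter). Among these compounds, this is the first single-place reading at this position, and it shows that these two aryl groups cannot be told apart here: a ring with chlorine and a ring with only carbon read alike. No measurement on hand accounts for this equivalence.

Open, going by these compounds, is whether an unsubstituted phenyl or a 4-methoxyphenyl on the same chain would stay level with these two aryl groups or separate from them. Also open, on these data alone, is whether a longer chain carrying the aryl group would move the number, with the rest of compound 2 held fixed.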